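The compounds below may be only part of what the source reports. "The series", "measured", "known", "first", "only" and "open" are said of these compounds alone.

Measured so far in a functional assay on Ehrlich cells (Mus musculus) for cytotoxicity, tested at 25 ug/mL; a lower number here means a weaker effect, a higher number a stronger effect of the compound at the concentration tested:
compound 1, `COc1cc(N2C(N)=C(C#N)C(c3ccc([N+](=O)[O-])cc3)C3=C2CC(C)(C)CC3=O)cc(OC)c1OC`, gives 50%
compound 2, `COc1cc(N2C(N)=C(C#N)C(c3c(O)ccc4ccccc34)C3=C2CC(C)(C)CC3=O)cc(OC)c1OC`, gives 10%
compound 3, `COc1ccccc1C1C(C#N)=C(N)N(c2cc(OC)c(OC)c(OC)c2)C2=C1C(=O)CC(C)(C)C2`, gives 65%

Compound 2 stands lowest of the three in this assay. Its nearest neighbour is compound 1, reached by reversing the step of a number 40 percentage points lower from compound 1 to compound 2 (beyond the scatter); its furthest is compound 3, separated by the step of a number 55 percentage points higher from compound 2 to compound 3 (beyond the scatter). Both steps lie beyond the scatter, so compound 2 is the weakest of the three.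

Compound 4, `COc1cc(N2C(N)=C(C#N)C(c3ccc(C)o3)C3=C2CC(C)(C)CC3=O)cc(OC)c1OC`, is not yet measured. Its change from compound 2: 5-methylfuran-2-yl in place of 2-hydroxynaphthalen-1-yl on a saturated ring carbon.

Within the data shown here, the steps that bear on this change are the two that remove the 2-hydroxynaphthalen-1-yl group from the saturated ring carbon: the reverse of a number 40 percentage points lower from compound 1 to compound 2 (beyond the scatter) and a number 55 percentage points higher from compound 2 to compound 3 (beyond the scatter), both large upward moves. Between the two replacement groups themselves the difference was only modest, a number 15 percentage points higher from compound 1 to compound 3 (beyond the scatter). From the compounds shown here alone, whether a 5-methylfuran-2-yl group behaves like those two groups is unknown from these three compounds alone; no other five-membered heteroaryl has been tested here.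

The expectation is therefore a large upward step in this assay, a number 35 percentage points higher from compound 2 to compound 4 (beyond the scatter). Compound 4 is estimated at 45%, with a range from 20% to 70%.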

Compound 4, a percentage reported as activity, at one concentration (the size of the read-out at that concentration, not a potency): 31%
The estimate for compound 4 lay 14 percentage points above the measured number, within the range that was stated.
By their numbers in this assay, from the lowest: compound 2; then compound 4; then compound 1; then compound 3.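

In this assay, the position on the saturated ring carbon now carries a five-membered aromatic ring with 1 hetero atom, and 5-methylfuran-2-yl lands inside the span set by the six-membered aromatic groups, not at either end of it: a number 21 percentage points higher from compound 2 to compound 4 (beyond the scatter), alongside a number 19 percentage points lower from compound 1 to compound 4 (beyond the scatter) and a number 34 percentage points lower from compound 3 to compound 4 (beyond the scatter). The loss of 2-hydroxynaphthalen-1-yl thus goes with a higher number for all three groups seen in its place (compound 1, compound 3 and compound 4), but the size of that gain depends on the entering group, and the smaller 5-methylfuran-2-yl recovers less of it than 4-nitrophenyl or 2-methoxyphenyl. Nothing measured for this series explains this order of groups.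

From the compounds shown here alone, whether the lower number of compound 4 follows the ring size, the ring oxygen or the methyl remains open, and unsubstituted furan-2-yl, thiophen-2-yl or pyridin-3-yl would separate these. Also open, going by these compounds, is whether the hydroxyl or the second fused ring of 2-hydroxynaphthalen-1-yl goes with the low number of compound 2, a question that 2-hydroxyphenyl and naphthalen-1-yl would address.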